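The compounds below may be only part of what the source reports. "The series", "measured", "known", "first", "only" and "open" are said of these compounds alone.

Working notes on the series. In a functional assay on DU-145 cells (Homo sapiens) for cytotoxicity, read by MTT assay (on this read-out higher numbers stand for weaker inhibition and lower numbers for stronger inhibition), compound 1 `COC(C)CO[C@H](CC=C(C)C)C1=CC(=O)c2c(O)ccc(O)c2C1=O` gives 16600 nM. For the measured compounds named here, compound 3 `CC(C)=CC[C@@H](OC(=O)CC(O)c1ccccc1)C1=CC(=O)c2c(O)ccc(O)c2C1=O` gives 17000 nM in this assay, a number within the scatter of compound 1, whereas compound 2 `CCCCC(CC(=O)O[C@H](CC=C(C)C)C1=CC(=O)c2c(O)ccc(O)c2C1=O)OC(C)=O` gives 67700 nM, the one value beyond the scatter of compound 1. Going by the values given here, the only measured step, a 4.0-fold lower number from compound 2 to compound 3 (0.60 log units; beyond the scatter), runs from an acetoxy-bearing chain to a hydroxy(phenyl)methyl group on the ester side, so it touches the present change only loosely. Compound 4 `CCC(CO[C@H](CC=C(C)C)C1=CC(=O)c2c(O)ccc(O)c2C1=O)OC(C)=O` differs from compound 1 by 1-acetoxypropyl in place of 1-methoxyethyl on a saturated chain carbon bound to an oxygen on a saturated carbon. Since compound 2, the other acetoxy-bearing ether/ester side chain, gives 67700 nM, a modest rise is expected, a 1.5-fold higher number from compound 1 to compound 4 (0.18 log units; within the scatter), though an outcome within the scatter is plausible. Compound 4 is therefore estimated at 25000 nM, range 10000 nM to 60000 nM.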

Compound 4, half-maximal inhibitory concentration: 25400 nM
Compound 4: middle estimate off by 1.0-fold (0.01 log units), on the low side; measured number inside the range.
By their numbers in this assay, from the lowest: compounds 1, 3 and 4 (each within the scatter of the next); then compound 2.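

In this assay, 1-acetoxypropyl in place of 1-methoxyethyl on a saturated chain carbon bound to an oxygen on a saturated carbon gives a 1.5-fold higher number from compound 1 to compound 4 (0.18 log units; within the scatter), so this position accepts a group of 7 heavy atoms in place of 4 with a step inside the scatter. Nothing available explains this outcome. The compounds shown change the acetoxy group and the chain together, leaving their separate contributions open. As far as these compounds go, what an amine or a carboxylic acid would do at this place also remains open.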